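The source may hold more compounds than are shown below. What is called first, only, known or untested is meant among the compounds shown, and "the series" means these compounds.

Three compounds built on a shared core were examined in an ADME assay on C8166 cells (Homo sapiens) for inhibition, read by MTT assay, with a stated time of 72 h; on this read-out higher numbers stand for lower toxicity in this test and lower numbers for higher toxicity in this test. Compound 1 `CC(C)(C)Oc1cc2oc(-c3ccccc3)cc(=O)c2c(O)c1O` gives 40.5 ug/mL, compound 3 `CC(C)(C)Oc1cc(O)c2c(=O)cc(-c3ccc(O)cc3)oc2c1` gives 25 ug/mL, and compound 2 `O=c1cc(-c2ccc(O)c(O)c2)oc2cc(OCc3ccc(F)cc3)cc(O)c12` gives 16.2 ug/mL. Compound 2 gives the smallest of the three numbers, yet compound 3 lies within the scatter of it, so those two cannot be ordered; compound 1 stands beyond the scatter at a higher number, and is thus less toxic in this test. Compound 4 `O=c1cc(-c2ccccc2)oc2cc(OCc3ccc(F)cc3)cc(O)c12` has not yet been measured in this assay. It differs from compound 2 in one place: phenyl in place of 3,4-dihydroxyphenyl on an aromatic carbon. For the measured compounds named here, no measured pair differing in only one place is available, so the size of this step rests on the three numbers alone. Compound 1 carries a phenyl and gives the highest number, while the two compounds carrying hydroxyl-bearing rings sit lower, which points to a modest move toward less toxicity for compound 4, though with compounds that differ in several places at once this remains tentative. Compound 4 is therefore expected to give about 25 ug/mL in this assay, within a range of 10 ug/mL to 60 ug/mL. The step expected from this is a 1.5-fold higher number from compound 2 to compound 4 (0.19 log units; within the scatter).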

Compound 4, half-maximal cytotoxic concentration: 8.35 ug/mL
The estimate for compound 4 lay 3.0-fold (0.48 log units) above the measured number; the whole stated range lies above it.
By their numbers in this assay, from the lowest: compounds 4, 2, 3 and 1 (each within the scatter of the next, the first and the last beyond it).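

In this assay, for the compounds shown here, the pair gives the first direct reading of this position, a 1.9-fold lower number from compound 2 to compound 4 (0.29 log units; within the scatter), so compound 2 and compound 4 cannot be ordered. On this aromatic carbon next to the ring oxygen, phenyl in place of 3,4-dihydroxyphenyl removes two hydroxyl groups, with their hydrogen-bond donors and acceptors, yet the read-out stays within the usual scatter for this one pair. No accompanying measurement bears on why the two compounds give such close numbers.

The compounds shown leave open whether an amine or a carboxylic acid on this phenyl ring would carry the number beyond the scatter. They also leave open whether the same exchange would give a similarly small step with a different group elsewhere on the shared core.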